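A few compounds are considered here, and "the series" means these few. Any claim that something is new, unique, unknown or untested is made for them only; others in the source may bear on it.

Three compounds have been measured in a functional assay on B16-F10 cells (Mus musculus) for cytotoxicity, read by MTT assay, with a stated time of 48 h; on this read-out higher numbers stand for weaker inhibition and lower numbers for stronger inhibition:

compound 1, `O=C(NCc1ccccc1)N(Cc1ccccn1)n1cnnc1`, giving 31000 nM
compound 2, `CCc1ccc(NC(=O)N(Cc2cc(OC)c(OC)c(OC)c2)n2cnnc2)cc1`, giving 24700 nM
compound 3, `COc1ccc(CN(C(=O)Nc2cc(C(F)(F)F)cc(C(F)(F)F)c2)n2cnnc2)cc1OC`, giving 8540 nM

Compound 2 stands second highest of these three numbers. Its nearest neighbour is compound 1, whose number is higher by a margin that lies within the usual scatter of this assay, so the two cannot be told apart. Compound 3 shows a lower number than compound 2, and that gap lies beyond the scatter.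

Compound 4 is `COc1cc(CN(C(=O)Nc2ccc(C#N)cc2)n2cnnc2)cc(OC)c1OC`, not yet measured. It differs from compound 2 in one place: cyano in place of ethyl on an aromatic carbon. The rest of the molecule, including the urea linkage and the shared core, is unchanged.

Among the compounds with values here, no pair of measured compounds differs by exactly this change, so there is no measured step to lean on. The three numbers shown span a narrow range, and nothing among them points to a move in either direction for a cyano in place of an ethyl. The step from compound 2 to compound 4 is therefore expected to be a 1.2-fold lower number from compound 2 to compound 4 (0.09 log units; within the scatter), that is, none beyond the scatter. Compound 4 is estimated at 20000 nM, with a range from 7000 nM to 60000 nM.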

Compound 4, half-maximal inhibitory concentration: 21000 nM
The estimate for compound 4 lay 1.1-fold (0.02 log units) below the measured number; the range from low to high includes it.
By their numbers in this assay, from the lowest: compound 3; then compounds 4, 2 and 1 (each within the scatter of the next).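

In this assay, within the data shown here, the first measured step at this position, cyano in place of ethyl on an aromatic carbon para to a large group, gives a 1.2-fold lower number from compound 2 to compound 4 (0.07 log units; within the scatter), so the 4-ethylphenyl and 4-cyanophenyl versions of this urea cannot be told apart. The two groups have the same count of heavy atoms, but cyano brings a triple bond and a hydrogen-bond acceptor that ethyl lacks, and in this single pair those differences come with no change beyond the scatter. Nothing measured here offers an explanation for this outcome.

The compounds shown leave open whether another group at this same place, such as an amine, a carboxylic acid or a longer chain, would shift the number beyond the scatter. They also leave open whether cyano in place of ethyl would give a similarly small step with a different group at the other end of the urea, since one pair cannot establish a general rule.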